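This account rests on a few compounds, and the source may have more. Where it says the series, first, only, none or still open, it means among the compounds named here.

Measured compounds:
compound 1 `COc1cccc(S(=O)(=O)/C=C/c2ccccn2)c1`, 74%
compound 2 `COc1cccc(S(=O)(=O)/C=C/c2ncccc2F)c1`, 31%
compound 3 `COc1ccc(S(=O)(=O)/C=C/c2ccccn2)cc1`, 56%

All three were tested in an ADME assay on microsomes from liver (Homo sapiens) for metabolic stability, read by LC-MS, using NADPH, with stated times of 5 min and 30 min, tested at 1 uM; a higher number here means that more of the compound is left, a lower number that less of the compound is left. Compound 1 and compound 2 differ in one place: fluoro in place of hydrogen on an aromatic carbon. Among the measured compounds shown here, the step of a number 43 percentage points lower from compound 1 to compound 2 (beyond the scatter) is the only single change whose size is known here. Compound 3 shares its atoms with compound 1 but has them joined differently; the difference between the two cores is not broken down here. Compound 3 gives 56%, and compound 1 gives 74%.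

Compound 4 `COc1ccc(S(=O)(=O)/C=C/c2ncccc2F)cc1` has not been measured. It stands to compound 3 as compound 2 stands to compound 1: fluoro in place of hydrogen on an aromatic carbon, the same change at the same kind of place. Compound 4 is expected to show a step of a number 38 percentage points lower from compound 3 to compound 4 (beyond the scatter) in this assay, because the same change gave a number 43 percentage points lower from compound 1 to compound 2 (beyond the scatter). That rests on a single pair, so the size is uncertain. Compound 4 is therefore estimated at 18%, with a range from 5% to 38%.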

Compound 4, percent of the compound remaining: 1.8%
Compound 4: the middle estimate sits 16.2 percentage points above what was measured; measured number outside the range, below it.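

In this assay, fluoro in place of hydrogen on an aromatic carbon gave a number 54.2 percentage points lower from compound 3 to compound 4 (beyond the scatter). Set beside the earlier step, the change carried from one core to the other with no difference in size that can be told apart: the same change on two cores in this assay, a number 43 percentage points lower (beyond the scatter) from compound 1 to compound 2 and a number 54.2 percentage points lower (beyond the scatter) from compound 3 to compound 4, 11.2 percentage points apart, within the scatter of two such steps This shows that the large step recurred on both cores, but two pairs cannot show that it would hold on any other core in the series, and they do not show why the number falls.

The compounds shown leave open what a group other than fluoro would do at that same place, such as chloro, a methyl group or a nitrile, and whether any of these would keep the number closer to that of the parent with hydrogen. As far as these compounds go, they also all carry the methoxy group, so it remains open how the step would behave if an ethoxy group, an amine or a carboxylic acid stood in its place.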